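Cytotoxicity notes: exchanging the substituent on the core

The source may report more compounds than this note shows. Statements on the series, on what has been measured and on what is new or still open speak of the compounds shown alone.

Of the compounds shown here, three have been read in an ADME assay on HepG2 cells (Homo sapiens) for cytotoxicity, read by luminescence, CellTiter-Glo and ATP content, with a stated time of 72 h; on this read-out higher numbers stand for an effect only at larger amounts of compound and lower numbers for an effect already at smaller amounts. Compound 1 `COc1ccc(Oc2ccc3c(NCCCNCc4cccc(OC)c4O)ccnc3c2)cc1` gives 5500 nM in this assay. Compound 2 `COc1cccc(CNCCCNc2ccnc3cc(CCC(C)C)ccc23)c1O` gives 5390 nM in this assay, and compound 3 `COc1cccc(CNCCCNc2ccnc3cc(Oc4ccccc4)ccc23)c1O` gives 6800 nM in this assay. Compound 3 thus holds the highest of the three numbers, but its gaps to compound 1 and to compound 2 both lie within the scatter, so the three cannot be ordered.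

The known steps are a 1.0-fold lower number from compound 1 to compound 2 (0.01 log units; within the scatter), a 1.2-fold higher number from compound 1 to compound 3 (0.09 log units; within the scatter) and a 1.3-fold higher number from compound 2 to compound 3 (0.10 log units; within the scatter). Every one of them stays within the scatter, whichever group is exchanged.

Compound 4 `COc1cccc(CNCCCNc2ccnc3cc(Cc4ccc(F)cc4Cl)ccc23)c1O` is not yet measured. Its difference from compound 3 is 2-chloro-4-fluorobenzyl in place of phenoxy on an aromatic carbon. For the measured compounds named here, the steps that bear on this change are the two exchanges at the same aromatic carbon, a 1.0-fold lower number from compound 1 to compound 2 (0.01 log units; within the scatter) and a 1.3-fold higher number from compound 2 to compound 3 (0.10 log units; within the scatter); both were flat. Going by the values given here, nothing measured so far suggests that a further exchange at that position would move the number beyond the scatter, so the expectation for this assay is a step of a 1.1-fold lower number from compound 3 to compound 4 (0.05 log units; within the scatter), in no particular direction. Compound 4 is therefore expected to give about 6000 nM in this assay, with a range from 3000 nM to 12000 nM.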

Compound 4, half-maximal effective concentration: 2350 nM
Estimate against measurement, compound 4: 2.6-fold (0.41 log units) above, outside the stated range (below it).
By their numbers in this assay, from the lowest: compound 4; then compounds 2, 1 and 3 (each within the scatter of the next).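

At the aromatic carbon that is meta to a fused ring and para to a fused ring, 4-methoxyphenoxy, isopentyl and phenoxy had left this assay flat, but this position is not insensitive to every exchange: placing 2-chloro-4-fluorobenzyl there gives a 2.9-fold lower number from compound 3 to compound 4 (0.46 log units; beyond the scatter), alongside a 2.3-fold lower number from compound 2 to compound 4 (0.36 log units; beyond the scatter) and a 2.3-fold lower number from compound 1 to compound 4 (0.37 log units; beyond the scatter). All three steps run the same way and lie beyond the scatter, though each is modest, so compound 4 alone separates from the otherwise unresolved set, with an effect already at smaller amounts of compound. The exchange from phenoxy removes the oxygen, adds a carbon link and brings in chlorine and fluorine all at once, and no available evidence ties the shift to any one of these features.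

A plain benzyl group, or a benzyl carrying only chlorine or only fluorine, would separate the contribution of the carbon link from that of each halogen. On these data alone, how an amine or a carboxylic acid at this aromatic carbon would read in this assay remains open, as does whether a longer chain bearing the same halogenated ring would follow compound 4.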